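The compounds below may be only part of what the source reports. "The series", "measured", "known", "first", "only" and "open" are said of these compounds alone.

Compound 1 `Cn1c(=O)cnn(CCCCN2CCN(c3cccc(O)c3)CC2)c1=O`: in an assay for displacement of a labelled ligand from Adrenergic receptor alpha-1 (Homo sapiens) (on this read-out lower numbers stand for stronger inhibition and higher numbers for weaker inhibition), compound 1 gives > 10000 nM, which is a limit of the assay rather than a number.
Compound 2 `Cn1c(=O)cnn(CCCCN2CCN(c3ccc(F)cn3)CC2)c1=O`: in this assay compound 2 gives > 10000 nM, likewise a limit.
Compound 3 `Cn1c(=O)cnn(CCCCN2CCN(c3ncccc3F)CC2)c1=O`: in this assay compound 3 gives > 10000 nM, again a limit.

All three values therefore sit at the same place, (the limit of > 10000 nM in this assay, at which 3 of the 3 values shown sit), and compound 3 stands there with the other two; no number separates them. Compound 4 `Cn1c(=O)cnn(CCCCN2CCN(c3cccc(F)n3)CC2)c1=O` differs from compound 3 by 6-fluoropyridin-2-yl in place of 3-fluoropyridin-2-yl on an amine nitrogen in a ring. The measured steps that bear on such a swap, a step that the two limits leave unreadable from compound 1 to compound 2, a step that the two limits leave unreadable from compound 1 to compound 3 and a step that the two limits leave unreadable from compound 2 to compound 3, have no readable size because both ends sit at the limit of > 10000 nM in this assay, at which 3 of the 3 values shown sit. They give no sign that any of these aryl groups reaches measurable binding. Compound 4 is thus expected to remain at the limit as well, with an estimate of 15000 nM (range 5000 nM to 50000 nM). The expected step that the limit leaves unreadable from compound 3 to compound 4 is none beyond the scatter.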

Compound 4, inhibition constant: > 10000 nM
Compound 4 gave a limit, no number; the forecaster's own chance of this, stated with the estimate: 85%; the middle value lies beyond the limit too.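

Among the compounds shown here, compound 4 gives a limit, not a number, so no step linking it to compound 1, compound 2 or compound 3 can be read: the limit of > 10000 nM in this assay, at which 4 of the 4 values shown sit. In this assay the compounds shown leave open how strongly any of them binds and how their groups on the amine nitrogen rank.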